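The source may hold more compounds than are shown below. What is called first, only, known or untested is meant among the compounds shown, and "the series" means these compounds.

Three measured compounds share one core and differ only in the ring carried on the amide nitrogen. In a functional assay on HeLa cells (Homo sapiens) for inhibition, read by MTT assay, with a stated time of 72 h (a higher number here means a weaker inhibitor, a lower number a stronger inhibitor), compound 1 `Cc1noc(C)c1-c1cnc(N)c(Oc2ccc(C(=O)Nc3ccc(Cl)cc3)cc2)n1` gives 2230 nM. In this assay compound 2 `Cc1noc(C)c1-c1cnc(N)c(Oc2ccc(C(=O)Nc3cccc(Cl)c3)cc2)n1` gives 1340 nM, and compound 3 `Cc1noc(C)c1-c1cnc(N)c(Oc2ccc(C(=O)Nc3cccc(Cl)n3)cc2)n1` gives 25500 nM. Compound 2 has the lowest number of the three, but its distance to compound 1, a 1.7-fold lower number from compound 1 to compound 2 (0.22 log units; within the scatter), stays within the scatter, whereas a 19-fold higher number from compound 2 to compound 3 (1.28 log units; beyond the scatter) and an 11-fold higher number from compound 1 to compound 3 (1.06 log units; beyond the scatter) are large. Compound 4 `Cn1cc(-c2cnc(N)c(Oc3ccc(C(=O)Nc4cccc(Cl)c4)cc3)n2)cn1` leaves the amide end untouched and instead alters the shared core: 1-methyl-1H-pyrazol-4-yl in place of 3,5-dimethyl-1,2-oxazol-4-yl on an aromatic carbon. Within the data shown here, none of the measured steps touches this place; all three concern only the ring on the amide nitrogen, so they give no direct guide to the size or direction of the new step. With nothing to point either way, compound 4 is expected to show a step of a 1.1-fold higher number from compound 2 to compound 4 (0.05 log units; within the scatter), within the scatter but with a wide range. Compound 4 is therefore estimated at 1500 nM, between 450 nM and 5000 nM.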

Compound 4, half-maximal inhibitory concentration: 4460 nM
For compound 4 the middle estimate is 3.0-fold (0.47 log units) below the measured one; low and high end bracket the measured number.
By their numbers in this assay, from the lowest: compounds 2, 1 and 4 (each within the scatter of the next, the first and the last beyond it); then compound 3.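

Among these compounds, the position on the shared core that carries the five-membered ring, untouched by the earlier compounds, turns out to matter in this assay: putting 1-methyl-1H-pyrazol-4-yl in place of 3,5-dimethyl-1,2-oxazol-4-yl gives a 3.3-fold higher number from compound 2 to compound 4 (0.52 log units; beyond the scatter). The step is modest, yet both groups are single five-membered aromatic rings with two hetero atoms and the same counts of hydrogen-bond donors and acceptors, and in this pair those matching counts do not bring matching numbers. Nothing available explains the shift.

Among the compounds shown here, this change is seen only with the 3-chlorophenyl amide of compound 2, and whether it would carry over to the 4-chlorophenyl amide of compound 1 stays open. Also open, from the compounds shown here alone, is how this position would respond to a plain phenyl ring or an amine.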